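The compounds below may be only part of what the source reports. "The series", "measured", "known", "first", "only" and "open" are said of these compounds alone.

Measured compounds:
- Compound 1, `Cc1cc(C(=O)O)c(C)n1-c1cccc(C2CC2)c1`, gives 580 nM in an assay on cells for inhibition of Palmitoleoyl-protein carboxylesterase NOTUM variant C330S (Homo sapiens), read by fluorescence, with a stated time of 40 min; on this read-out higher numbers stand for weaker inhibition and lower numbers for stronger inhibition.
- Compound 2, `Cc1cccc(N2CCC(C(=O)O)C2)c1`, gives 49000 nM in this assay.

Compound 2 stands highest of the two numbers in this assay, that is, it is the weaker inhibitor of the pair, and compound 1 sits well beyond the usual scatter below it. The two compounds share little beyond the carboxylic acid, so nothing here separates the contribution of any single part.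

Compound 3, `N#Cc1cccc(N2CCC(C(=O)O)C2)c1`, differs from compound 2 in one place: cyano in place of methyl on an aromatic carbon. Going by the values given here, no measured pair shows this kind of exchange, so there is no step to lean on. The expectation is a modest shift toward stronger inhibition, small enough that it may not clear the scatter, estimated as a step of a 1.6-fold lower number from compound 2 to compound 3 (0.21 log units; within the scatter). Compound 3 is therefore expected to come in at about 30000 nM in this assay, with a range from 8000 nM to 100000 nM.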

Compound 3, half-maximal inhibitory concentration: 42000 nM
Estimate against measurement, compound 3: 1.4-fold (0.15 log units) below; the measured number falls inside the stated range.
By their numbers in this assay, from the lowest: compound 1; then compounds 3 and 2 (each within the scatter of the next).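

Putting cyano in place of methyl on this aromatic carbon gives a 1.2-fold lower number from compound 2 to compound 3 (0.07 log units; within the scatter) in this assay, so the two compounds cannot be told apart. At this position, then, a methyl with 1 heavy atom and no hydrogen-bond acceptor reads the same as a cyano with 2 heavy atoms and 1 hydrogen-bond acceptor, at least on this shared core and at this weak level of inhibition. No measurement here offers an explanation for this result.

From the compounds shown here alone, whether an amine, a hydroxyl or a longer chain on the same carbon would shift the number beyond the scatter remains open. Compound 1 differs from both compound 2 and compound 3 in more than one place, so which of its parts goes with its much lower number also stays unresolved.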